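A few compounds are considered here, and "the series" means these few. Any claim that something is new, unique, unknown or untested is made for them only; others in the source may bear on it.

Among the compounds with values here, compound 2 `CC1=C(/C=C/C(=O)/C=C/c2cccc([N+](=O)[O-])c2)C(C)(C)CCC1O` gives 5800 nM in a functional assay on PC-3 cells (Homo sapiens) for cytotoxicity, read by MTT assay, with a stated time of 72 h (on this read-out lower numbers stand for stronger inhibition and higher numbers for weaker inhibition), the low end of the two numbers measured so far, though within the scatter of its only neighbour, compound 1 `CC1=C(/C=C/C(=O)/C=C/c2cccc(C#N)c2)C(C)(C)CCC1O`, which gives 7200 nM in this assay. Within the data shown here, the single measured step, a 1.2-fold lower number from compound 1 to compound 2 (0.09 log units; within the scatter), shows that swapping nitro for cyano on the aromatic ring moved the read-out by no more than the scatter. Compound 3 `COc1cccc(/C=C/C(=O)/C=C/C2=C(C)C(O)CCC2(C)C)c1` differs from compound 2 as follows: methoxy in place of nitro on an aromatic carbon. Among the measured compounds shown here, no measured step addresses a methoxy at this place on the shared core; the one recorded exchange at that place was within the scatter, so no shift beyond the scatter is expected in this assay either, with the uncertainty widened for lack of a direct precedent. The expected step is a 1.2-fold higher number from compound 2 to compound 3 (0.08 log units; within the scatter). Compound 3 is estimated at 7000 nM in this assay, with a range from 2500 nM to 20000 nM.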

Compound 3, half-maximal inhibitory concentration: 6500 nM
Compound 3: the middle estimate sits 1.1-fold (0.03 log units) above what was measured, within the range that was stated.
By their numbers in this assay, from the lowest: compounds 2, 3 and 1 (each within the scatter of the next).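

In this assay the exchange of nitro for methoxy gives a 1.1-fold higher number from compound 2 to compound 3 (0.05 log units; within the scatter) and the exchange of cyano for methoxy gives a 1.1-fold lower number from compound 1 to compound 3 (0.04 log units; within the scatter), both within the scatter. Within the data shown here, the earlier pair compared only two nitrogen-bearing groups, whereas methoxy carries no nitrogen, and across compounds 1, 2 and 3 this place on the aromatic ring still shows no step beyond the scatter. No supporting data accompany these values to explain why the numbers stay so close.

Going by these compounds, it remains open whether an amine, a carboxylic acid or a longer chain at this place would also stay within the scatter. The three compounds also leave open what happens when the group sits on another ring carbon or when the shared core itself changes.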